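Homologating the hydroxyalkyl arm on the amine of compound 2

The source may hold more compounds than are shown below. What is called first, only, known or untested is meant among the compounds shown, and "the series" means these compounds.

Compound 2 `C[C@@H](O)CNC(C)(C)C(=O)N[C@@H]1CCc2ccccc2N(Cc2ccc(-c3ccccc3-c3nn[nH]n3)cc2)C1=O` gives the lowest number of the two measured, 300 nM in a functional assay (Pituitary gland cell) with Rattus norvegicus as the target; a lower number here means that less compound is needed, a higher number that more compound is needed for the effect. Compound 1 `CC(C)[C@H](O)CNC(C)(C)CC(=O)N[C@@H]1CCc2ccccc2N(Cc2ccc(-c3ccccc3-c3nn[nH]n3)cc2)C1=O` gives 1000 nM, and the step of a 3.3-fold lower number from compound 1 to compound 2 (0.52 log units; beyond the scatter) is modest. Compound 3 `C[C@@H](O)CCNC(C)(C)C(=O)N[C@@H]1CCc2ccccc2N(Cc2ccc(-c3ccccc3-c3nn[nH]n3)cc2)C1=O` carries 2-hydroxypropyl in place of 1-hydroxyethyl on a saturated chain carbon bound to an amine nitrogen. Among the measured compounds shown here, only the step from compound 1 to compound 2 bears on this, and it changed two things at once, so it guides weakly; a small shift, if any, toward a higher number is expected. Compound 3 is estimated at 450 nM, between 150 nM and 1500 nM, a step of a 1.5-fold higher number from compound 2 to compound 3 (0.18 log units; within the scatter).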

Compound 3, concentration for half-maximal effect: 100 nM
Compound 3: the middle estimate sits 4.5-fold (0.65 log units) above what was measured, and the stated range ends above it.
By their numbers in this assay, from the lowest: compound 3; then compound 2; then compound 1.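

In this assay, 2-hydroxypropyl in place of 1-hydroxyethyl on a saturated chain carbon bound to an amine nitrogen gives a 3.0-fold lower number from compound 2 to compound 3 (0.48 log units; beyond the scatter), so the longer arm lowers the number at this position. For the whole group on the carbonyl carbon, 1-((3-hydroxybutyl)amino)-1-methylethyl in place of 2-((2-hydroxy-3-methylbutyl)amino)-2-methylpropyl gives a 10-fold lower number from compound 1 to compound 3 (1.00 log units; beyond the scatter). No measurement shown accounts for either step. Open, as far as these compounds go, is whether a still longer hydroxyalkyl chain on the amine continues this trend, and whether a carboxylic acid can stand in place of the hydroxyl.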